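Swapping acetyl for dimethylamino on a shared core

The source may hold more compounds than are shown below. What is called first, only, known or untested is meant among the compounds shown, and "the series" means these compounds.

Compound 1 `COc1cc(C)cc(-c2c(-c3ccnc(-c4ccc(C(C)=O)cc4)c3)cnn2CC#N)c1` and compound 2 `Cc1cc(O)cc(-c2nn(CC#N)cc2-c2ccnc(-c3ccc(Oc4ccccc4)cc3)c2)c1` were both tested in a functional assay on CAKI-1 cells (Homo sapiens) for inhibition, read by sulforhodamine B assay, with a stated time of 48 h; on this read-out higher numbers stand for weaker inhibition of growth and lower numbers for stronger inhibition of growth. In this assay compound 1 gives > 100000 nM, which is a limit of the assay rather than a number. Compound 1 therefore stands at the limit of > 100000 nM in this assay, at which 1 of the 2 values shown sits. In this assay compound 2 gives 5780 nM. Within the data shown here, compound 2 differs from compound 1 in more than one place, so their two values show only that compound 2 has a measured number where compound 1 has a limit.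

Compound 3 `COc1cc(C)cc(-c2c(-c3ccnc(-c4ccc(N(C)C)cc4)c3)cnn2CC#N)c1` has not yet been measured. It differs from compound 1 in one place: dimethylamino in place of acetyl on an aromatic carbon. Among the measured compounds shown here, no measured pair in this set shows this change, so the size of the step is not known from the data; compound 1 sits at the limit of > 100000 nM in this assay, at which 1 of the 2 values shown sits, leaving room only toward stronger inhibition of growth. The step from compound 1 to compound 3 is expected to be an at least 2.5-fold lower number from compound 1 to compound 3 (0.39 log units; beyond the scatter), with wide uncertainty. Compound 3 is estimated at 40000 nM in this assay, with a range from 8000 nM to 200000 nM.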

Compound 3, concentration for total growth inhibition: 89.3 nM
Compound 3: middle estimate off by 450-fold (2.65 log units), on the high side, outside the stated range (below it).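

In this assay, exchanging 4-acetylphenyl for 4-(dimethylamino)phenyl gives an at least 1100-fold lower number from compound 1 to compound 3 (3.04 log units; beyond the scatter), so this aromatic carbon, para to a large group, is a place where the choice of one group separates a limit of the assay from a measured number. The two groups match in heavy-atom count, in hydrogen-bond donors and acceptors and in net charge, so the size of the step does not follow those counts; what differs is that acetyl carries an oxygen and a double bond outside aromatic rings, where dimethylamino carries a nitrogen. The step can be given only as a lower bound, because the value for compound 1 is a limit and not a number: the limit of > 100000 nM in this assay, at which 1 of the 3 values shown sits.

The compounds shown leave open how an unsubstituted amino group, a morpholine ring or a methoxy group on this same carbon would read in this assay, and so whether the nitrogen alone or dimethylamino as a whole goes with the step. They also leave open whether the same exchange would give a step of similar size on a core carrying hydroxy in place of methoxy.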